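The source may report more compounds than this note shows. Statements on the series, on what has been measured and on what is new or still open speak of the compounds shown alone.

Three chlorine-bearing compounds were measured in a physicochemical assay for metabolic stability, at 40 degrees C; on this read-out higher numbers stand for a longer-lived compound and lower numbers for a shorter-lived compound. Compound 1 `CC1(C)C(=O)N(CCCS(=O)(=O)O)C(C)(C)N1Cl` gives > 5970 h in this assay, which is a limit of the assay rather than a number. Compound 2 `CN1CC(C)(CO)N(Cl)C1=O` gives > 1390 h in this assay, again a limit. Compound 3 `CC1(C)CN(CCS(=O)(=O)O)C(=O)N1Cl` gives > 2200 h in this assay, also a limit; compound 3 thus stands at the limit of > 2200 h in this assay, at which 1 of the 3 values shown sits, and every value gathered so far is a limit rather than a number. Compound 4 `CC1(C)CN(CCS(=O)(=O)CCCS(=O)(=O)O)C(=O)N1Cl` has not yet been measured. It differs from compound 3 in one place: 3-sulfopropyl in place of hydroxy on a sulfonyl sulfur. The change is expected to move the half-life little, if at all, with no step beyond the scatter: a step that the limit leaves unreadable from compound 3 to compound 4. Compound 4 is estimated to give about 3000 h in this assay, within a range from 1000 h to 10000 h, most likely reported as a limit once more.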

Compound 4, half-life: > 2680 h
Compound 4: no number, only a limit (the forecaster's own chance of this, stated with the estimate: 85%); the middle value does not contradict the limit.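

Compound 3 and compound 4 each gave only a limit, and the size of the step between them cannot be read. The compounds shown leave open the actual half-life of every compound in this assay.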